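From Compound 1 to Compound 3: Amino Leaves, Benzyloxy Enters

The source may hold more compounds than are shown below. What is called first, only, known or untested is meant among the compounds shown, and "the series" means these compounds.

Compound 1 `NC(=O)CC[C@H](NC(=O)CN(c1ncnc2c1ncn2C1CCCCO1)C1CC1)C(=O)OCc1ccccc1` was tested in a functional assay on the whole organism (Tail, strain ICR) with Mus musculus as the target, in the tail flick test, with a stated time of 150 min, at a dose of 25 umol/kg by the oral route (on this read-out lower numbers stand for a weaker effect and higher numbers for a stronger effect at the one dose given), where compound 1 gives 10.7%, the lower of the two measured numbers. Compound 2 `C[C@H](NC(=O)CN(c1nc(Cl)nc2[nH]cnc12)C1CC1)C(=O)OCc1ccccc1` gives 23% in this assay, but it differs from compound 1 in several places, so only the two values themselves can be set side by side. Compound 3 `O=C(CN(c1ncnc2c1ncn2C1CCCCO1)C1CC1)N[C@@H](CCC(=O)OCc1ccccc1)C(=O)OCc1ccccc1` is not yet measured and differs from compound 1 in one place: benzyloxy in place of amino on a carbonyl carbon. Among the measured compounds shown here, with only two values to go on, a small upward step is expected, and the step this expectation means is a number 4.3 percentage points higher from compound 1 to compound 3 (within the scatter), likely within the scatter. Compound 3 is therefore estimated at 15%, ranging from 3% to 35%.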

Compound 3, a percentage reported as activity, at one dose (the size of the read-out at that dose, not a potency): 14.1%
Compound 3: middle estimate off by 0.9 percentage points, on the high side; the range from low to high includes it.
By their numbers in this assay, from the lowest: compounds 1, 3 and 2 (each within the scatter of the next, the first and the last beyond it).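

Replacing amino with benzyloxy on the carbonyl carbon comes with a number 3.4 percentage points higher from compound 1 to compound 3 (within the scatter) in this assay. At this one dose, the tail flick read-out therefore does not separate the small carbamoyl end from the much larger benzyloxycarbonyl end, which carries an added aromatic ring and lacks the hydrogen-bond donor of amino. Nothing measured here gives a reason for this result. On these data alone, whether a carboxylic acid or a methyl ester on this carbonyl carbon would read the same remains open. So does the effect of a longer chain leading to it.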